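Swapping Vinyl for Methyl on a Receptor Ligand Series

The source may report more compounds than this note shows. Statements on the series, on what has been measured and on what is new or still open speak of the compounds shown alone.

Four compounds sharing one core were examined for their ability to block a human receptor for a lipid signalling molecule. Compound 1 `CCc1cc(C(C)=O)c(O)cc1OCCCCCCC#N` and compound 2 `C=CCc1cc(C(C)=O)c(O)cc1OCCCCCCC#N` carry the same long chain ending in a nitrile; compound 3 `C=CCc1cc(C(C)=O)c(O)cc1OCc1cccc(C#N)c1` and compound 4 `CCc1cc(C(C)=O)c(O)cc1OCc1cccc(C#N)c1` carry instead a benzyl group bearing a nitrile. In an assay on isolated protein for binding affinity to leukotriene B4 receptor 1 (Homo sapiens), tested at 1 uM (on this read-out higher numbers stand for more inhibition at the one concentration tested (going by the name of the read-out) and lower numbers for less inhibition), compound 1 gives 73% and compound 2 gives 63%. Compound 3 gives 58% in this assay.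

Compound 2 and compound 1 differ in one place: methyl in place of vinyl on a saturated chain carbon bound to an aromatic carbon. This change gave a number 10 percentage points higher from compound 2 to compound 1 (within the scatter). The same kind of change separates compound 3 from compound 4: methyl in place of vinyl on a saturated chain carbon bound to an aromatic carbon. How the core of compound 2 differs from the core of compound 3 is not broken down here.

Among the compounds with values here, because the single measured instance of this change is a number 10 percentage points higher from compound 2 to compound 1 (within the scatter), and because compound 3 gives 58%, compound 4 is expected to land close to its parent, with a step of roughly a number 7 percentage points higher from compound 3 to compound 4 (within the scatter) that stays within the usual scatter. Compound 4 is thus estimated at 65% in this assay. The estimate for compound 4 is expected to range from 50% to 80%. Within the data shown here, with only one earlier example of the change, on a different side chain, the expected step rests on thin ground.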

Compound 4, a percentage reported as inhibition, at one concentration (the size of the read-out at that concentration, not a potency): 61%
Compound 4: middle estimate off by 4 percentage points, on the high side, and the stated range covers the measured number.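

In this assay, replacing allyl with ethyl on the core with the nitrile-bearing benzyl group, which amounts to methyl in place of vinyl on a saturated chain carbon bound to an aromatic carbon, gave a number 3 percentage points higher from compound 3 to compound 4 (within the scatter) on the core of compound 3. Set beside the earlier case on the long nitrile chain, the two steps are no further apart than repeated measurements would place them, so the change behaves alike on both cores as far as this read-out can tell: the same change on two cores in this assay, a number 10 percentage points higher (within the scatter) from compound 2 to compound 1 and a number 3 percentage points higher (within the scatter) from compound 3 to compound 4, 7 percentage points apart, within the scatter of two such steps. This does not show that swapping vinyl for methyl raises the inhibition at all, since neither step stands clear of the scatter, and two pairs of compounds cannot establish a rule for other cores in the series, nor can a reading at a single concentration give a potency.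

The compounds shown leave open what a longer chain such as butyl, or a chain ending in an amine, would do at this same place on the core. They also leave open whether the step would stay this small if a carboxylic acid took the place of the nitrile on the side chain.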